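Fluoro in place of chloromethyl on the benzamide ring

The source may report more compounds than this note shows. Statements on the series, on what has been measured and on what is new or still open speak of the compounds shown alone.

Compound 1, `O=C(Nc1ccc(S(=O)(=O)N2CCCC2)cc1)c1ccc(C(F)(F)F)cc1`: > 300000 nM
Compound 2, `O=C(Nc1ccc(S(=O)(=O)N2CCCC2)cc1)c1ccc(CCl)cc1`: 11000 nM

In an ADME assay on Vero cells (Chlorocebus sabaeus) for cytotoxicity, read by MTT assay (a lower number here means that less compound is tolerated, a higher number that more compound is tolerated), compound 2 gives 11000 nM. For compound 1 the value > 300000 nM is a limit of the assay, not a number. For the measured compounds named here, compound 2 therefore holds the only number in this assay; the other value is a limit (the limit of > 300000 nM in this assay, at which 1 of the 2 values shown sits). Going by the values given here, the one measured step, an at least 27-fold lower number from compound 1 to compound 2 (1.43 log units; beyond the scatter), is the sole guide.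

Compound 3, `O=C(Nc1ccc(S(=O)(=O)N2CCCC2)cc1)c1ccc(F)cc1`, is the next compound. The change is fluoro in place of chloromethyl on an aromatic carbon. It removes the chloromethyl that compound 2 carries, the same group whose entry in the measured step came with the large fall from compound 1 to compound 2. Compound 3 is therefore expected to move back toward the limit seen for compound 1, with a large rise as an 18-fold higher number from compound 2 to compound 3 (1.26 log units; beyond the scatter). The estimate for compound 3 in this assay is 200000 nM, with a range from 50000 nM to 300000 nM.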

Compound 3, half-maximal cytotoxic concentration: > 300000 nM
Compound 3: only a limit was reported (the forecaster's own chance of this, stated with the estimate: 60%); middle value at least 1.5-fold (0.17 log units) from the limit.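

Fluoro in place of chloromethyl on the aromatic carbon gives, in this assay, an at least 27-fold higher number from compound 2 to compound 3 (1.43 log units; beyond the scatter), so the chloromethyl compound now stands apart from two neighbours that differ from it in this one place, not from the trifluoromethyl compound alone. The comparison of compound 1 with compound 3 cannot be read, as both values are limits. Of the compounds shown, only the one carrying chloromethyl gives a number, and the other two stop at the same limit: the limit of > 300000 nM in this assay, at which 2 of the 3 values shown sit.

On these data alone, whether the lower number belongs to chloromethyl alone, or would also come with bromomethyl, hydroxymethyl or a plain methyl at this place, stays open. As far as these compounds go, how compound 1 and compound 3 rank against each other also stays open.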